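Solubility of a methoxy-bearing amide analogue

This account rests on a few compounds, and the source may have more. Where it says the series, first, only, none or still open, it means among the compounds named here.

Measured compounds:
- Compound 1, `CNC(=O)c1cc(C(=O)N[C@H]2[C@@H]3COC[C@@H]32)cc2c1OC[C@H]2c1cccc(OC)c1`, >= 186 ug/mL in a physicochemical assay for solubility; a higher number here means a more soluble compound, a lower number a less soluble compound
- Compound 2, `CNC(=O)c1cc(C(=O)Nc2cnn(C)c2)cc2c1OC[C@H]2c1ccccc1`, >= 189 ug/mL
- Compound 3, `CNC(=O)c1cc(C(=O)NC2CC2)cc2c1OC[C@H]2c1ccccc1`, >= 190 ug/mL

All three of these values are limits of this assay rather than numbers. For compound 3 the value >= 190 ug/mL is a limit, so its true solubility is known only to lie at or beyond that point (the limit of >= 190 ug/mL in this assay, at which 1 of the 3 values shown sits). The same holds for compound 1 (the limit of >= 186 ug/mL in this assay, at which 1 of the 3 values shown sits) and for compound 2 (the limit of >= 189 ug/mL in this assay, at which 1 of the 3 values shown sits).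

Compound 4 is `CNC(=O)c1cc(C(=O)NC2CC2)cc2c1OC[C@H]2c1cccc(OC)c1`. Compared with compound 3 it carries methoxy in place of hydrogen on an aromatic carbon.

Going by the values given here, the only step among the measured compounds is a step that the two limits leave unreadable from compound 2 to compound 3, and as both ends are limits its size cannot be read. Among the compounds with values here, no measured step covers the methoxy change itself. Compound 1, which also bears a 3-methoxyphenyl group, sits at a limit, which at least gives no sign that this group pushes solubility down into the measurable range.

Compound 4 is therefore expected to reach the limit of this assay as well, with an estimated step that the limit leaves unreadable from compound 3 to compound 4 that is no larger than the scatter. The estimate for compound 4 is 200 ug/mL, in the range 120 ug/mL to 350 ug/mL.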

Compound 4, solubility: >= 161 ug/mL
Compound 4 ended at the assay's limit (the forecaster's own chance of this, stated with the estimate: 85%); the middle value lies beyond the limit too.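

Compound 4 gives only a limit in this assay, as do compound 1 and compound 3, and the steps from compound 3 and compound 1 to compound 4 therefore cannot be read. The compounds shown leave open how far each true value lies beyond its limit, and whether the methoxy group changes it at all.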